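The source may hold more compounds than are shown below. What is called first, only, known or untested is meant among the compounds shown, and "the series" means these compounds.

In a functional assay on MKN-74 cells (Homo sapiens) for antiproliferative activity, with a stated time of 24 h (on this read-out lower numbers stand for stronger inhibition and higher numbers for weaker inhibition), compound 1 `NC(=O)c1c(NC(=O)c2ccccc2Cl)sc2c1CCN(Cc1c(Cl)cccc1Cl)C2` gives 4740 nM, the lowest of the three numbers measured. Compound 2 `Cc1ccc(C(=O)Nc2sc3c(c2C(N)=O)CCN(Cc2c(Cl)cccc2Cl)C3)cc1` gives 12300 nM and compound 3 `NC(=O)c1c(NC(=O)c2ccccc2F)sc2c1CCN(Cc1c(Cl)cccc1Cl)C2` gives 7430 nM; the steps between them are a 2.6-fold higher number from compound 1 to compound 2 (0.41 log units; beyond the scatter), a 1.6-fold higher number from compound 1 to compound 3 (0.20 log units; within the scatter) and a 1.7-fold lower number from compound 2 to compound 3 (0.22 log units; within the scatter). Compound 4 `CSc1ccccc1NC(=S)N1CCc2c(sc(NC(=O)c3ccccc3Cl)c2C(N)=O)C1` differs from compound 1 elsewhere: a group of 11 heavy atoms (8 carbon, 1 nitrogen, 2 sulfur; one six-membered aromatic ring of carbon only) in place of a group of 9 heavy atoms (7 carbon, 2 chlorine; one six-membered aromatic ring of carbon only), on an amine nitrogen in a ring. All three measured steps vary the group on the carbonyl carbon and leave the substituent on the amine nitrogen in the ring untouched, so none bears directly on this change. The expectation therefore rests on compound 1 alone and carries wide bounds. The step from compound 1 to compound 4 is estimated as a 1.5-fold higher number from compound 1 to compound 4 (0.17 log units; within the scatter). Compound 4 is expected to give 7000 nM, between 2000 nM and 25000 nM.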

Compound 4, half-maximal inhibitory concentration: 13800 nM
Compound 4: middle estimate off by 2.0-fold (0.29 log units), on the low side; the measured number falls inside the stated range.
By their numbers in this assay, from the lowest: compounds 1, 3, 2 and 4 (each within the scatter of the next, the first and the last beyond it).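

In this assay, the group on the amine nitrogen in a ring moves the number: replacing 2,6-dichlorobenzyl gives a 2.9-fold higher number from compound 1 to compound 4 (0.46 log units; beyond the scatter). Going by these compounds alone, the earlier steps varied only the group on the carbonyl carbon, so this is the first reading at this position, and the large replacement still gives a measurable value. Nothing available accounts for the step.

Open, from the compounds shown here alone, is how a plain benzyl or a methyl on this nitrogen would read. Also open, going by these compounds, is whether the entering group's sulfur atoms or its double bond contribute to the step.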